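This account rests on a few compounds, and the source may have more. Where it says the series, first, only, none or still open, it means among the compounds named here.

Measured so far in a physicochemical assay for lipophilicity, using the shake flask method, in phosphate buffer, measured as octanol-water partition, at pH 7.4; a lower number here means a more polar compound, a higher number a more lipophilic compound:
compound 1 `COc1cc(-c2cc(C(=O)O)c3ccccc3n2)ccc1OCC(=O)Nc1cccc(F)c1`: 1.6
compound 2 `COc1cc(-c2cc(C(=O)O)c3ccccc3n2)ccc1OCC(=O)Nc1ccc(F)cc1`: 1.1

Compound 2 gives the lower of the two numbers in this assay, with compound 1 the higher of the pair. Going by the values given here, the only measured step, a number 0.50 log units lower from compound 1 to compound 2 (beyond the scatter), moves a fluorine from one position on the phenyl ring to another while the rest of the molecule stays the same, and that alone shifts the number by a modest but real amount.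

Compound 3 `COc1cc(-c2cc(C(=O)O)c3ccccc3n2)ccc1OCC(=O)Nc1ccccc1Cl` is not yet measured. It differs from compound 2 in one place: 2-chlorophenyl in place of 4-fluorophenyl on an amide-type nitrogen. Among the compounds with values here, no measured step covers an exchange of fluorine for chlorine, so the expectation can lean only on the single positional step already seen, which shows that a small change on this ring can move the number beyond the scatter. Compound 3 is therefore expected to sit somewhat higher than compound 2, by about a number 0.40 log units higher from compound 2 to compound 3 (beyond the scatter), with wide uncertainty on the direction. The estimate for compound 3 in this assay is 1.5, between 0.9 and 2.1.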

Compound 3, distribution coefficient: 1.6
Compound 3: middle estimate off by 0.10 log units, on the low side; the range from low to high includes it.
By their numbers in this assay, from the lowest: compound 2; then compounds 1 and 3 (each within the scatter of the next).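

In this assay, the exchange of 4-fluorophenyl for 2-chlorophenyl on the amide-type nitrogen gives a number 0.50 log units higher from compound 2 to compound 3 (beyond the scatter) and so shows that this position responds to a change of halogen together with its place on the ring, not only to a shifted fluorine. The exchange of 3-fluorophenyl for the same 2-chlorophenyl gives no change at the digits printed from compound 1 to compound 3 (within the scatter) and so shows that two different rings can give matching numbers here, which leaves compound 2 as the one that stands apart among the three. No measurement at hand explains why these rings behave as they do.

With fluorine and chlorine changing along with their places on the ring, the compounds shown cannot separate the halogen from its place, which 2-fluorophenyl or 4-chlorophenyl would do. They also leave open how plain phenyl, or a phenyl ring carrying an amine, would read at this nitrogen.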